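Methylating the azaindole nitrogen of compound 1

The source may report more compounds than this note shows. Statements on the series, on what has been measured and on what is new or still open speak of the compounds shown alone.

Measured compounds:
compound 1, `O=C(Nc1ccc(Oc2ccnc3[nH]ccc23)cc1)c1cc2cccnc2n(-c2ccccc2)c1=O`, 1580 nM
compound 2, `O=C(Nc1ccc(Oc2ccnc3[nH]ccc23)cc1)c1cc2cccnc2n(-c2ccc(F)cc2)c1=O`, 1360 nM
compound 3, `O=C(Nc1ccc(Oc2ccnc3[nH]ccc23)cc1)c1cc2cccnc2n(-c2ccc(Br)cc2)c1=O`, "not determined" (no result reported)

In a functional assay on U-87MG ATCC cells for antiproliferative activity against U-87 MG (Homo sapiens), read by MTT assay, with a stated time of 72 h (a higher number here means a weaker inhibitor, a lower number a stronger inhibitor), compound 1 gives 1580 nM, the highest of the two numbers reported, with compound 2 as its nearest neighbour. For the measured compounds named here, the only step measured, a 1.2-fold lower number from compound 1 to compound 2 (0.07 log units; within the scatter), is a fluoro in place of hydrogen on an aromatic carbon and lies within the scatter; compound 3, the bromo analogue, has no number. Compound 4, `Cn1ccc2c(Oc3ccc(NC(=O)c4cc5cccnc5n(-c5ccccc5)c4=O)cc3)ccnc21`, differs from compound 1 by methyl in place of hydrogen on an aromatic nitrogen. Going by the values given here, no measured step touches this part of the shared core, so there is no direct guide. Among the compounds with values here, the one step available concerns a distant aromatic carbon and was small; the change in compound 4 is a different kind and place, and its effect cannot be read from it. Compound 4 is therefore expected to give an estimated 3200 nM in this assay, within a range of 1000 nM to 10000 nM, a step of a 2.0-fold higher number from compound 1 to compound 4 (0.31 log units; beyond the scatter) toward a weaker inhibitor, with wide uncertainty.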

Compound 4, half-maximal inhibitory concentration: 5030 nM
Compound 4: middle estimate off by 1.6-fold (0.20 log units), on the low side; the measured number falls inside the stated range.
By their numbers in this assay, from the lowest: compounds 2 and 1 (each within the scatter of the next); then compound 4.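

Unlike the fluoro step on a distant aromatic carbon, which stayed within the scatter, the change on the aromatic nitrogen of the five-membered ring registers in this assay, where methyl in place of hydrogen gives a 3.2-fold higher number from compound 1 to compound 4 (0.50 log units; beyond the scatter) toward a weaker inhibitor. This is the only step shown that lies beyond the scatter, so this position is not indifferent to substitution, although a single methyl costs only a modest amount of activity. Nothing available explains the loss.

The compounds shown leave open whether a longer chain such as ethyl, or a chain ending in an amine or a carboxylic acid, on this nitrogen would weaken the compound further or recover activity. They also leave open whether the same methyl step would hold with the fluoro group of compound 2 in place.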